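Thiazole acetic acids: compound 1 to compound 3

The compounds below may be only part of what the source reports. "The series", "measured", "known", "first", "only" and "open" are said of these compounds alone.

Measured so far:
compound 1, `COc1cc(-c2nc(C(c3ccc(F)cc3)c3ccc(F)cc3)sc2CC(=O)O)ccn1`: 380 nM
compound 2, `O=C(O)Cc1sc(C(c2ccccc2)c2ccccn2)nc1-c1ccc(Cl)cc1`: 1900 nM

Both were run in an in vitro functional assay on HEK285-7 cells for antagonist activity at prostaglandin D2 receptor 2 (Homo sapiens), read by BRET and beta-arrestin recruitment; a higher number here means a weaker inhibitor, a lower number a stronger inhibitor. Compound 1 gives the lower of the two numbers; compound 2 gives a number beyond the scatter above it. Among the compounds with values here, no pair that differs in one place has been measured, so the two values show only that these two compounds sit apart.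

Compound 3, `CS(=O)(=O)Nc1cccc(-c2nc(C(c3ccc(F)cc3)c3ccc(F)cc3)sc2CC(=O)O)c1`, is not yet measured. It differs from compound 1 in one place: 3-(methanesulfonamido)phenyl in place of 2-methoxypyridin-4-yl on an aromatic carbon.

Within the data shown here, with no measured step to lean on, the expected step is a 1.5-fold lower number from compound 1 to compound 3 (0.18 log units; within the scatter), toward a lower number, of a size that may not clear the scatter. Compound 3 is therefore estimated at 250 nM, in the range 80 nM to 800 nM.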

Compound 3, half-maximal inhibitory concentration: 370 nM
Beside the measured number, compound 3's estimate is 1.5-fold (0.17 log units) below it; measured number inside the range.
By their numbers in this assay, from the lowest: compounds 3 and 1 (each within the scatter of the next); then compound 2.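

In this assay, within the data shown here, the step of a 1.0-fold lower number from compound 1 to compound 3 (0.01 log units; within the scatter) is the first one-place reading at this position. This aromatic carbon takes 3-(methanesulfonamido)phenyl as well as 2-methoxypyridin-4-yl, with the larger group and its added hydrogen-bond donor leaving the number within the scatter. Nothing at hand explains this result.

Still open, on these data alone, is how an unsubstituted phenyl would read at this position, which would separate the ring change from the substituent. As far as these compounds go, an amine or a carboxylic acid on that ring is equally open.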